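Acetyl in Place of Oxazole Carbonyl: Expected Toxicity Read-out

The source may hold more compounds than are shown below. What is called first, only, known or untested is meant among the compounds shown, and "the series" means these compounds.

Compound 1 `COc1ccc(-c2cnc(NC(=O)c3ccn[nH]3)n2C)cc1`: > 100000 nM
Compound 2 `COc1ccc(-c2cnc(NC(=O)c3cccc(Br)c3)n2C)cc1`: > 100000 nM
Compound 3 `COc1ccc(-c2cnc(NC(=O)c3cnco3)n2C)cc1`: > 100000 nM

In a toxicity assay on THP-1 cells (Homo sapiens) for inhibition (on this read-out lower numbers stand for higher toxicity in this test and higher numbers for lower toxicity in this test), compound 3 gives > 100000 nM, and this value is a limit of the assay rather than a number. The same is true of compound 1, whose value in this assay is a limit. The same is true of compound 2, whose value in this assay is a limit. All three measured values therefore sit at one limit (the limit of > 100000 nM in this assay, at which 3 of the 3 values shown sit), so compound 3 stands level with both of its neighbours as far as the data can tell.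

Compound 4 `COc1ccc(-c2cnc(NC(C)=O)n2C)cc1` differs from compound 3 in one place (methyl in place of 1,3-oxazol-5-yl on a carbonyl carbon). The measured steps that touch compound 3, a step that the two limits leave unreadable from compound 1 to compound 3 and a step that the two limits leave unreadable from compound 2 to compound 3, are both unreadable, as is a step that the two limits leave unreadable from compound 1 to compound 2; none of them gives a readable size. Since every measured value sits at the limit (the limit of > 100000 nM in this assay, at which 3 of the 3 values shown sit), the step of a number no higher from compound 3 to compound 4 (the limit leaves the size open) is expected to be none beyond the scatter. Compound 4 is therefore estimated at 100000 nM in this assay, with a range from 50000 nM to 300000 nM, and most likely again only a limit.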

Compound 4, half-maximal cytotoxic concentration: > 100000 nM
Compound 4: a limit, no number; the forecaster's own chance of this, stated with the estimate: 85%; the middle value lies on the limit itself.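

In this assay, going by these compounds alone, compound 4 gives a limit and not a number, so no step linking compound 1, compound 2 or compound 3 to compound 4 can be read: the limit of > 100000 nM in this assay, at which 4 of the 4 values shown sit. The compounds shown leave open whether the group on the carbonyl carbon has any bearing on the result in this assay.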